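A repeated amine swap at the chain end

The source may hold more compounds than are shown below. What is called first, only, known or untested is meant among the compounds shown, and "the series" means these compounds.

Compound 1 `COc1cc2c(Oc3ccc(NC(=O)c4nn(-c5ccccc5OC(F)(F)F)c(=O)cc4C)cc3F)ccnc2cc1OCCCN1CCC(C)CC1`: 290 nM
Compound 2 `COc1cc2c(Oc3ccc(NC(=O)c4nn(-c5ccccc5OC(F)(F)F)c(=O)cc4C)cc3F)ccnc2cc1OCCCN1CCN(C)CC1`: 260 nM
Compound 3 `COc1cc2c(Oc3ccc(NC(=O)c4nn(-c5cccc(F)c5)c(=O)cc4C)cc3F)ccnc2cc1OCCCN1CCC(C)CC1`: 250 nM

All three values come from a functional assay on NCI-H460 cells (Homo sapiens) for inhibition, read by MTT assay, with a stated time of 72 h; on this read-out lower numbers stand for stronger inhibition and higher numbers for weaker inhibition. Compound 1 and compound 2 share one core and differ by 4-methylpiperazin-1-yl in place of 4-methylpiperidin-1-yl on a saturated chain carbon, three bonds along the chain from an oxygen on an aromatic ring; this change gave a 1.1-fold lower number from compound 1 to compound 2 (0.05 log units; within the scatter). Compound 1 and compound 3 differ in the core by 3-fluorophenyl in place of 2-(trifluoromethoxy)phenyl on an aromatic nitrogen, and that step read a 1.2-fold lower number from compound 1 to compound 3 (0.06 log units; within the scatter). For the measured compounds named here, compound 3 thus stands with the lowest of the three numbers, but every gap between the three compounds lies within the scatter, so no compound can be called more potent than another.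

Compound 4 `COc1cc2c(Oc3ccc(NC(=O)c4nn(-c5cccc(F)c5)c(=O)cc4C)cc3F)ccnc2cc1OCCCN1CCN(C)CC1` has not yet been measured in this assay. It carries the same change as the first pair, (4-methylpiperazin-1-yl in place of 4-methylpiperidin-1-yl on a saturated chain carbon, three bonds along the chain from an oxygen on an aromatic ring), now made on the core of compound 3. Because the earlier occurrence gave a 1.1-fold lower number from compound 1 to compound 2 (0.05 log units; within the scatter), the step from compound 3 to compound 4 is expected to be about as small, a 1.1-fold lower number from compound 3 to compound 4 (0.04 log units; within the scatter). Compound 4 is therefore estimated to give 230 nM in this assay, likely between 120 nM and 450 nM.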

Compound 4, half-maximal inhibitory concentration: 260 nM
Estimate against measurement, compound 4: 1.1-fold (0.05 log units) below, within the range that was stated.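

Carried onto a second core in this assay, 4-methylpiperazin-1-yl in place of 4-methylpiperidin-1-yl gave a 1.0-fold higher number from compound 3 to compound 4 (0.02 log units; within the scatter), and the two occurrences of this change agree: the same change on two cores in this assay, a 1.1-fold lower number (0.05 log units; within the scatter) from compound 1 to compound 2 and a 1.0-fold higher number (0.02 log units; within the scatter) from compound 3 to compound 4, 1.2-fold (0.06 log units) apart, within the scatter of two such steps.

The aryl change, 3-fluorophenyl in place of 2-(trifluoromethoxy)phenyl on an aromatic nitrogen, gave no change at the digits printed from compound 2 to compound 4 (within the scatter), and its two occurrences agree as well: the same change on two cores in this assay, a 1.2-fold lower number (0.06 log units; within the scatter) from compound 1 to compound 3 and no change at the digits printed (within the scatter) from compound 2 to compound 4, 1.2-fold (0.06 log units) apart, within the scatter of two such steps.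

For the compounds shown here, both changes thus stay within the scatter on either core, so these four compounds show that the two swaps leave the numbers indistinguishable wherever they are made, but with no step large enough to follow, they do not show that a real potency gain or loss would carry from one core to another.

Still open, from the compounds shown here alone, is whether another amine at the chain end, such as morpholine or dimethylamine, or a longer chain would give a step beyond the scatter. The same question stands for an unsubstituted phenyl on the aromatic nitrogen, and for whether any such larger step would hold on both cores.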